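The source may report more compounds than this note shows. Statements on the series, on what has been measured and on what is new or still open speak of the compounds shown alone.

Measured so far:
Compound 1 `CN(C)CCn1cnnc1-c1cc(Oc2ccc(NC(=O)N/N=C/c3ccc(O)c(O)c3)cc2F)ccn1` — 1930 nM
Compound 2 `CN(C)CCn1cnnc1-c1cc(Oc2ccc(NC(=O)N/N=C/c3cc(Br)c(O)c(Br)c3)cc2F)ccn1` — 3760 nM

In a functional assay on NCI-H460 cells (Homo sapiens) for cytotoxicity, read by MTT assay, with a stated time of 72 h (on this read-out lower numbers stand for stronger inhibition and higher numbers for weaker inhibition), compound 2 stands at the highest of the two numbers, with 3760 nM. Among the compounds with values here, its nearest neighbour is compound 1, and the only step available, a 1.9-fold higher number from compound 1 to compound 2 (0.29 log units; within the scatter), lies within the scatter. Compound 3 `CN(C)CCn1cnnc1-c1cc(Oc2ccc(NC(=O)N/N=C/c3ccc(O)c(F)c3)cc2F)ccn1` differs from compound 2 in one place: 3-fluoro-4-hydroxyphenyl in place of 3,5-dibromo-4-hydroxyphenyl on a carbon with a double bond to nitrogen. This change sits where that single step was measured, and that step was small. No movement beyond the scatter is therefore expected, with the step estimated as a 1.4-fold lower number from compound 2 to compound 3 (0.16 log units; within the scatter). Compound 3 is expected to give 2600 nM, within a range of 1000 nM to 6500 nM in this assay.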

Compound 3, half-maximal inhibitory concentration: 2620 nM
Estimate against measurement, compound 3: 1.0-fold (0.00 log units) below; low and high end bracket the measured number.
By their numbers in this assay, from the lowest: compounds 1, 3 and 2 (each within the scatter of the next).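

In this assay, this position on the carbon with a double bond to nitrogen now holds three different substituted phenyl groups, and both new steps stay within the scatter: swapping two bromines for one fluorine gives a 1.4-fold lower number from compound 2 to compound 3 (0.16 log units; within the scatter) and fluoro in place of hydroxy on an aromatic carbon gives a 1.4-fold higher number from compound 1 to compound 3 (0.13 log units; within the scatter). So neither the halogen swap nor the loss of one hydroxy separates these compounds. Nothing measured here explains these numbers. As far as these compounds go, all three groups keep the 4-hydroxy, so an unsubstituted phenyl remains untested here. From the compounds shown here alone, whether an amine or a carboxylic acid on this ring would move the number beyond the scatter also stays open.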